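Phenyl for Methyl on a Selenium-Containing Ring

This account rests on a few compounds, and the source may have more. Where it says the series, first, only, none or still open, it means among the compounds named here.

Compound 3 `Cc1c[se]c(N/N=C/c2ccc(Cl)cc2)n1` gives the highest of the three numbers in a functional assay on HepG2 cells (Homo sapiens) for cytotoxicity, read by XTT assay, with a stated time of 72 h (on this read-out higher numbers stand for weaker inhibition and lower numbers for stronger inhibition), with 56500 nM. Among the compounds with values here, compound 1 `NC(=[Se])N/N=C/c1ccc(Cl)cc1` gives 13000 nM, and compound 2 `COc1ccc(/C=N/NC(N)=[Se])cc1` gives 11300 nM; the only measured step, a 1.2-fold lower number from compound 1 to compound 2 (0.06 log units; within the scatter), lies within the scatter. Compound 4 `Clc1ccc(/C=N/Nc2nc(-c3ccccc3)c[se]2)cc1` differs from compound 3 by phenyl in place of methyl on an aromatic carbon, on an aromatic carbon of a five-membered aromatic ring with 1 nitrogen and 1 selenium. Within the data shown here, no measured step touches this ring or this kind of exchange, so the data give no direction for it. The expected step is a 1.3-fold lower number from compound 3 to compound 4 (0.10 log units; within the scatter), and it is not expected to exceed the scatter. The estimate for compound 4 is 45000 nM, ranging from 12000 nM to 150000 nM.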

Compound 4, half-maximal inhibitory concentration: 42500 nM
For compound 4 the middle estimate is 1.1-fold (0.02 log units) above the measured one; measured number inside the range.
By their numbers in this assay, from the lowest: compounds 2 and 1 (each within the scatter of the next); then compounds 4 and 3 (each within the scatter of the next).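

Putting phenyl in place of methyl on the aromatic carbon next to the ring nitrogen gives a 1.3-fold lower number from compound 3 to compound 4 (0.12 log units; within the scatter), so this position carries the added six-membered aromatic ring without a change beyond the scatter. Compounds 1 and 2 do not have the five-membered aromatic ring with 1 nitrogen and 1 selenium, so they could not show this. No measurement bears on why the larger group leaves the number within the scatter. The compounds shown leave open whether an amine or a carboxylic acid on this carbon would move the number beyond the scatter. They also leave open how methoxy in place of chloro would read on compound 4.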